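Swapping the aryl group on a piperazine sulfonamide

A few compounds are considered here, and "the series" means these few. Any claim that something is new, unique, unknown or untested is made for them only; others in the source may bear on it.

Measured compounds:
- compound 1, `CCCn1c(=O)[nH]c2nc(-c3ccc(S(=O)(=O)N4CCN(C)CC4)cc3)[nH]c2c1=O`: 7%
- compound 2, `CCCn1c(=O)[nH]c2nc(-c3ccc(S(=O)(=O)N4CCN(c5cccc(Br)c5)CC4)cc3)[nH]c2c1=O`: 27%

In an assay on CHO cells for displacement of a labelled ligand from adenosine receptor A3 (Homo sapiens), read by scintillation counting, with a stated time of 45 min, tested at 1 uM, in the presence of a further agent that is not named here (on this read-out lower numbers stand for less inhibition and higher numbers for more inhibition at the one concentration tested (going by the name of the read-out)), compound 1 gives 7% and compound 2 gives 27%. Compound 2 stands highest of the two, with the step of a number 20 percentage points higher from compound 1 to compound 2 (beyond the scatter). Compound 3, `CCCn1c(=O)[nH]c2nc(-c3ccc(S(=O)(=O)N4CCN(c5ccccc5F)CC4)cc3)[nH]c2c1=O`, carries 2-fluorophenyl in place of 3-bromophenyl on an amine nitrogen in a ring. Among the measured compounds shown here, no measured step bears directly on this aryl-to-aryl swap; the only step known is from compound 1 to compound 2, where an aryl group entered. Since compound 3 keeps an aryl group, the expected step of a number 5 percentage points lower from compound 2 to compound 3 (within the scatter) is small, within the scatter. For compound 3 the estimated value is 22%, expected between 8% and 40%.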

Compound 3, a percentage reported as inhibition, at one concentration (the size of the read-out at that concentration, not a potency): 9%
Compound 3: the middle estimate sits 13 percentage points above what was measured; the range from low to high includes it.
By their numbers in this assay, from the lowest: compounds 1 and 3 (each within the scatter of the next); then compound 2.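

In this assay there is a number 18 percentage points lower from compound 2 to compound 3 (beyond the scatter) and a number 2 percentage points higher from compound 1 to compound 3 (within the scatter) so an aryl group on this ring nitrogen does not by itself raise the number. The rise seen with 3-bromophenyl therefore does not extend to every aryl group. Nothing available explains this difference. This swap changes both the halogen and its place on the phenyl ring, and the compounds shown cannot separate the two. Open, too, is how 3-fluorophenyl or 2-bromophenyl, each changing only one of these, would compare with compound 2.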